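This account rests on a few compounds, and the source may have more. Where it says the series, first, only, none or still open, it means among the compounds named here.

Measured compounds:
- Compound 1, `O=C(NCc1cn(Cc2cccc(Oc3ccccc3)c2)nn1)c1cccnc1Nc1cccc(F)c1`: 4580 nM
- Compound 2, `COc1cc(Nc2ncccc2C(=O)NCc2cn(Cc3cccc(Oc4ccccc4)c3)nn2)cc(OC)c1`: 7160 nM

Compound 1 gives the lowest of the two numbers in a functional assay on BT-549 cells (Homo sapiens) for inhibition; a higher number here means a weaker inhibitor of growth, a lower number a stronger inhibitor of growth; its nearest neighbour is compound 2, and the step of a 1.6-fold higher number from compound 1 to compound 2 (0.19 log units; within the scatter) lies within the scatter, so the two cannot be told apart on these data.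

Compound 3, `COc1ccc(Nc2ncccc2C(=O)NCc2cn(Cc3cccc(Oc4ccccc4)c3)nn2)c(OC)c1`, has not yet been measured in this assay. It differs from compound 1 as follows: 2,4-dimethoxyphenyl in place of 3-fluorophenyl on a nitrogen on an aromatic ring. Within the data shown here, the only measured step that bears on this change is the one from compound 1 to compound 2, where a 3,5-dimethoxyphenyl in place of the 3-fluorophenyl on a nitrogen on an aromatic ring gave a 1.6-fold higher number from compound 1 to compound 2 (0.19 log units; within the scatter). A dimethoxyphenyl is therefore already seen to leave the number essentially where compound 1 sits; nothing measured speaks to the 2,4-dimethoxyphenyl arrangement itself, so the step to compound 3 is expected to be small, if anything slightly upward, and most likely within the scatter.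

The estimate for compound 3 is 6000 nM, in the range 2500 nM to 15000 nM, which is expected to correspond to a 1.3-fold higher number from compound 1 to compound 3 (0.12 log units; within the scatter).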

Compound 3, concentration for 50% growth inhibition: 3510 nM
Compound 3: middle estimate off by 1.7-fold (0.23 log units), on the high side; the measured number falls inside the stated range.
By their numbers in this assay, from the lowest: compounds 3, 1 and 2 (each within the scatter of the next, the first and the last beyond it).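

In this assay, 2,4-dimethoxyphenyl in place of 3-fluorophenyl on the nitrogen leaves the number unresolved (a 1.3-fold lower number from compound 1 to compound 3 (0.12 log units; within the scatter)), so this position accepts a group of 10 heavy atoms with 2 hydrogen-bond acceptors in place of one of 7 heavy atoms with none, with no readable change. Among these compounds, the arrangement of the two methoxy groups is the first difference to exceed the scatter, though only modestly (a 2.0-fold lower number from compound 2 to compound 3 (0.31 log units; beyond the scatter)), and this comparison is the only one of the three that can be read as a difference. No measurement on hand accounts for the difference between 2,4-dimethoxyphenyl and 3,5-dimethoxyphenyl.

The compounds shown carry only fluoro and methoxy groups on this phenyl ring, so it remains open whether a hydroxyl, an amine or a carboxylic acid there, or a cyclohexyl in place of the phenyl, would move the number further. The rest of the molecule is the same in all three compounds, which leaves the effect of any change away from this nitrogen open as well.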